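Swapping a Small Amine for a Cyclopentylpiperazine

This account rests on a few compounds, and the source may have more. Where it says the series, first, only, none or still open, it means among the compounds named here.

Compound 2 `CNCc1nc(Nc2ccc(C(F)(F)F)cc2)c2ccc(-c3ncccc3C(F)(F)F)cc2n1` gives 26 nM in a functional assay for antagonist activity at transient receptor potential cation channel subfamily V member 1 (Homo sapiens); a higher number here means a weaker inhibitor, a lower number a stronger inhibitor. Compound 1 `OCCc1nc(Nc2ccc(C(F)(F)F)cc2)c2ccc(-c3ncccc3C(F)(F)F)cc2n1` gives 22 nM in this assay, and the gap between the two, a 1.2-fold higher number from compound 1 to compound 2 (0.07 log units; within the scatter), places them together rather than apart. Compound 3 `FC(F)(F)c1ccc(Nc2nc(CN3CCN(C4CCCC4)CC3)nc3cc(-c4ncccc4C(F)(F)F)ccc23)cc1` differs from compound 2 by 4-cyclopentylpiperazin-1-yl in place of methylamino on a saturated chain carbon bound to an aromatic carbon. For the measured compounds named here, the only measured step exchanged two small groups at the same place and barely moved the number, so it bears only loosely on this much larger exchange and gives no direction. Compound 3 is therefore expected to stay in the same region, with wider uncertainty: the estimate is 35 nM, within 10 nM to 120 nM, a step of a 1.3-fold higher number from compound 2 to compound 3 (0.13 log units; within the scatter).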

Compound 3, half-maximal inhibitory concentration: 8 nM
Compound 3: middle estimate off by 4.4-fold (0.64 log units), on the high side; the whole stated range lies above it.
By their numbers in this assay, from the lowest: compound 3; then compounds 1 and 2 (each within the scatter of the next).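

On a saturated chain carbon bound to an aromatic carbon, 4-cyclopentylpiperazin-1-yl, with its two rings, gives a lower number in this assay than either smaller group (a 3.3-fold lower number from compound 2 to compound 3 (0.51 log units; beyond the scatter); a 2.8-fold lower number from compound 1 to compound 3 (0.44 log units; beyond the scatter)). The earlier exchange of small groups stayed within the scatter, whereas these steps lie beyond it, so this position does respond to what it carries. No measurement available here accounts for the change.

Going by these compounds, whether the piperazine ring or the cyclopentyl on it matters more stays open. An unsubstituted piperazine or a morpholine at the same place would help separate the two.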